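This account rests on a few compounds, and the source may have more. Where it says the series, first, only, none or still open, it means among the compounds named here.

Compound 1 `O=[N+]([O-])c1ccc2[nH]c(CSCc3nc4ccccc4[nH]3)nc2c1` gives 13100 nM in a functional assay on MCF7 cells (Homo sapiens) for cytotoxicity, read by MTT assay, with a stated time of 48 h (on this read-out higher numbers stand for weaker inhibition and lower numbers for stronger inhibition), here.
Compound 2 `O=[N+]([O-])c1ccc2[nH]c(CSCc3nc4cc([N+](=O)[O-])ccc4[nH]3)nc2c1` gives 1740 nM in this assay here.
Compound 3 `O=C(CSCc1nc2cc([N+](=O)[O-])ccc2[nH]1)c1ccc(Cl)cc1` gives 2800 nM in this assay here.

Compound 3 thus lies within the scatter of compound 2, while the number of compound 1 stands higher than both. Compound 4 `CCOC(=O)CSCc1nc2cc([N+](=O)[O-])ccc2[nH]1` differs from compound 3 as follows: ethoxy in place of 4-chlorophenyl on a carbonyl carbon with ethoxy in place of 4-chlorophenyl on a carbonyl carbon. Going by the values given here, the only measured step, a 7.5-fold lower number from compound 1 to compound 2 (0.88 log units; beyond the scatter) for nitro in place of hydrogen on an aromatic carbon, lies elsewhere and offers no direct guide to this change. No shift beyond the scatter is therefore expected in this assay with the estimated step being a 1.6-fold higher number from compound 3 to compound 4 (0.21 log units; within the scatter) at most a slight one. For compound 4 the expected value is 4500 nM with an estimated range from 1500 nM to 13000 nM as the working expectation.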

Compound 4, half-maximal inhibitory concentration: > 100000 nM
Compound 4 gave a limit, no number; the forecaster's own chance of this, stated with the estimate: 5%; middle value at least 22-fold (1.34 log units) from the limit.
By their numbers in this assay, from the lowest: compounds 2 and 3 (each within the scatter of the next); then compound 1. At a limit, above all of these: compound 4.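

The group on the carbonyl carbon matters strongly in this assay: ethoxy in place of 4-chlorophenyl gives an at least 35-fold higher number from compound 3 to compound 4 (1.55 log units; beyond the scatter). The earlier step concerned only a nitro group on an aromatic carbon and said nothing about this place. Compound 4 gives a limit and no number: the limit of > 100000 nM in this assay, at which 1 of the 4 values shown sits.

The compounds shown do not separate the loss of the aromatic ring from the entry of ethoxy. Going by these compounds, how a plain phenyl, an amine or a carboxylic acid on this carbonyl carbon would read remains open.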